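Lengthening the alkyl chain from propyl to pentyl

The source may hold more compounds than are shown below. What is called first, only, known or untested is meant among the compounds shown, and "the series" means these compounds.

Compound 1, `O=C(Nc1ccccc1)C1CCN(C/C=C/c2ccccc2)CC1`: in a functional assay on MCF7 cells (Homo sapiens) for inhibition, read by MTT assay, with a stated time of 72 h (on this read-out lower numbers stand for stronger inhibition and higher numbers for weaker inhibition), compound 1 gives 60200 nM.
Compound 2, `Cc1ccc(NC(=O)C2CCN(C/C=C/c3ccccc3)CC2)cc1`: in this assay compound 2 gives 30000 nM.
Compound 3, `CCCc1ccc(NC(=O)C2CCN(C/C=C/c3ccccc3)CC2)cc1`: in this assay compound 3 gives 9030 nM.

Compound 3 stands lowest of the three numbers in this assay, its steps from compound 1 and from compound 2 both lying beyond the scatter, so it is the most potent of the measured set. The change to compound 4, `CCCCCc1ccc(NC(=O)C2CCN(C/C=C/c3ccccc3)CC2)cc1`, is ethyl in place of hydrogen on a saturated chain carbon, three bonds along the chain from an aromatic carbon. Among the measured compounds shown here, the steps that bear on it are those growing the same chain: a 6.7-fold lower number from compound 1 to compound 3 (0.82 log units; beyond the scatter) and a 3.3-fold lower number from compound 2 to compound 3 (0.52 log units; beyond the scatter), whereas a 2.0-fold lower number from compound 1 to compound 2 (0.30 log units; within the scatter). Each step along that chain so far has lowered the number, the larger ones beyond the scatter. Compound 4 is therefore expected to continue in the same direction, though a step as large as the earlier ones is not assured, so a modest lowering is estimated: a 2.0-fold lower number from compound 3 to compound 4 (0.30 log units; within the scatter). For compound 4 the estimated value in this assay is 4500 nM, within a range from 1500 nM to 13000 nM.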

Compound 4, half-maximal inhibitory concentration: 3740 nM
Compound 4: middle estimate off by 1.2-fold (0.08 log units), on the high side; the measured number falls inside the stated range.
By their numbers in this assay, from the lowest: compound 4; then compound 3; then compounds 2 and 1 (each within the scatter of the next).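

The lowering does not stop at propyl: in this assay, ethyl in place of hydrogen on a saturated chain carbon, three bonds along the chain from an aromatic carbon, gives a 2.4-fold lower number from compound 3 to compound 4 (0.38 log units; beyond the scatter). Pentyl also sets the longest chain clearly apart from the shorter ends of the series, with an 8.0-fold lower number from compound 2 to compound 4 (0.90 log units; beyond the scatter) and a 16-fold lower number from compound 1 to compound 4 (1.21 log units; beyond the scatter), the only step of this set printed as large, and no compound shown goes against the trend, although the first step from hydrogen to methyl stays within the scatter. Nothing measured here offers an explanation for this trend.

On these data alone, whether the number keeps falling with a longer chain such as heptyl or octyl remains open. So does how a branched tert-butyl group, or a chain ending in an amine or a carboxylic acid, would behave in its place.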